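Shrinking the Ring on the Amino Nitrogen

A few compounds are considered here, and "the series" means these few. Any claim that something is new, unique, unknown or untested is made for them only; others in the source may bear on it.

In a functional assay on A549 cells (Homo sapiens) for antiproliferative activity, read by MTT assay, with a stated time of 72 h (on this read-out lower numbers stand for stronger inhibition and higher numbers for weaker inhibition), compound 1 `O=C(Nc1ccc(Nc2nccc(NC3CCCCC3)n2)cc1)Nc1ccc(Cl)c(C(F)(F)F)c1` gives 7430 nM and compound 2 `O=C(Nc1ccc(Nc2nccc(NC3CCCC3)n2)cc1)Nc1ccc(Cl)c(C(F)(F)F)c1` gives 5880 nM on the same scale. For the measured compounds named here, these are the only two numbers so far, and the two compounds stand level: cyclopentyl in place of cyclohexyl gave a 1.3-fold lower number from compound 1 to compound 2 (0.10 log units; within the scatter) as its result. Compound 3 `O=C(Nc1ccc(Nc2nccc(NC3CC3)n2)cc1)Nc1ccc(Cl)c(C(F)(F)F)c1` makes the ring smaller again, through the change cyclopropyl in place of cyclopentyl on a nitrogen on an aromatic ring with cyclopropyl in place of cyclopentyl on a nitrogen on an aromatic ring. Going by the values given here, the single measured step is the only guide, and it also alters ring size on that nitrogen. It showed no real change, but the new ring lies outside the sizes tested, so the margin stays wide. The step expected in this assay is a 1.1-fold higher number from compound 2 to compound 3 (0.04 log units; within the scatter) and so none beyond the scatter. Compound 3 is estimated at 6500 nM within a likely range from 2800 nM to 15000 nM on this read-out.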

Compound 3, half-maximal inhibitory concentration: 18500 nM
Compound 3: middle estimate off by 2.8-fold (0.45 log units), on the low side; measured number above the stated range.
By their numbers in this assay, from the lowest: compounds 2 and 1 (each within the scatter of the next); then compound 3.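

Ring size on this nitrogen turns out to matter in this assay: cyclopropyl in place of cyclopentyl gave a 3.1-fold higher number from compound 2 to compound 3 (0.50 log units; beyond the scatter), and cyclopropyl in place of cyclohexyl gave a 2.5-fold higher number from compound 1 to compound 3 (0.40 log units; beyond the scatter). Compound 1 and compound 2 stand level, so across these three compounds the number does not climb steadily as the ring shrinks; only the smallest ring, with 3 heavy atoms, stands apart from the other two. Nothing available here accounts for this rise.

As far as these compounds go, how cyclobutyl would fare remains open, so the ring size at which the number starts to rise cannot be placed. Also open, from the compounds shown here alone, is whether an open-chain group such as isopropyl, or a ring carrying a hydroxyl group, would fit on the same nitrogen.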